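This account rests on a few compounds, and the source may have more. Where it says the series, first, only, none or still open, it means among the compounds named here.

Compound 2 `CC(c1cc2cc(-c3cnn(C)c3)cnc2cc1F)n1nnc2ncc(-c3ccc(C(N)=O)c(F)c3)nc21` stands level with compound 3 `CNC(=O)c1ccc(-c2cnc3nnn(C(C)c4cc5cc(-c6cnn(C)c6)cnc5cc4F)c3n2)cc1F` at the digits shown, the two together giving the lowest numbers of the three measured in a functional assay on SNU-5 cells (Homo sapiens) for inhibition, read by CCK-8 assay, with a stated time of 72 h; a higher number here means a weaker inhibitor, a lower number a stronger inhibitor. In this assay compound 2 gives 0.6 nM, compound 3 gives 0.6 nM, and compound 1 `CC(c1ccc2ncc(-c3cnn(C)c3)cc2c1)n1nnc2ncc(-c3ccc(C(N)=O)c(F)c3)nc21` gives 0.7 nM. The step of a 1.2-fold lower number from compound 1 to compound 2 (0.07 log units; within the scatter) lies within the scatter, as does the step of no change at the digits printed from compound 2 to compound 3 (within the scatter).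

Compound 4 `CC(c1c(F)cc2ncc(-c3cnn(C)c3)cc2c1F)n1nnc2ncc(-c3ccc(C(N)=O)c(F)c3)nc21` differs from compound 2 in one place: fluoro in place of hydrogen on an aromatic carbon. The new fluoro sits on an aromatic carbon of a six-membered aromatic ring of carbon only, part of a fused system of two rings, ortho to a fused ring, ortho to a large group, meta to a fluoro group and meta to a fused ring.

Going by the values given here, of the measured steps, only the step from compound 1 to compound 2 is of the same kind, a fluoro in place of hydrogen on an aromatic carbon, and it gave no shift beyond the scatter. The step from compound 2 to compound 3 concerns a different part of the molecule and was likewise flat. On this basis no step beyond the scatter is expected in this assay, in either direction, and a step of a 1.3-fold higher number from compound 2 to compound 4 (0.12 log units; within the scatter) is estimated. Compound 4 is therefore expected to give about 0.8 nM, with a range of 0.3 nM to 2.5 nM.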

Compound 4, half-maximal inhibitory concentration: 0.4 nM
For compound 4 the middle estimate is 2.0-fold (0.30 log units) above the measured one; low and high end bracket the measured number.
By their numbers in this assay, from the lowest: compounds 4, 2, 3 and 1 (each within the scatter of the next).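

In this assay the new fluoro, on an aromatic carbon of a six-membered aromatic ring of carbon only, ortho to a large group and ortho to a fused ring, gives a 1.5-fold lower number from compound 2 to compound 4 (0.18 log units; within the scatter), so this position takes a fluoro group with no shift beyond the scatter. Compound 4 carries it in addition to the fluoro group already present in compound 2, meta to the new one, which shows that a second such replacement stays as flat as the first, a 1.2-fold lower number from compound 1 to compound 2 (0.07 log units; within the scatter), with neither of these two steps going against that reading. Nothing given here bears on why this position reads so flat, and the result can only be described by its numbers.

As far as these compounds go, whether a chloro group, a methoxy group or an amine on this same aromatic carbon would also stay within the scatter of compound 2 remains open. Equally open, from the compounds shown here alone, is whether the methyl group on the amide nitrogen of compound 3, or a longer ethyl group there, would read the same alongside this added fluoro.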